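Adding a Third Methoxy to a Purine Benzyl Group

The compounds below may be only part of what the source reports. "The series", "measured", "known", "first", "only" and "open" are said of these compounds alone.

Compounds 1, 2 and 3 were tested in a functional assay on AGS cells (Homo sapiens) for antiproliferative activity, read by MTT assay, with a stated time of 48 h; on this read-out higher numbers stand for weaker inhibition of growth and lower numbers for stronger inhibition of growth. Compound 1 `COc1ccc(Cn2cnc3c(N(C)c4ccc(OC)cc4)ncnc32)cc1` gives only a limit of this assay, > 100000 nM. Compound 2 `COc1ccc(N(C)c2ncnc3c2ncn3Cc2ccc(OC)c(OC)c2)cc1` likewise reaches only a limit of this assay, > 100000 nM. The change from compound 1 to compound 2 is methoxy in place of hydrogen on an aromatic carbon, and the step that the two limits leave unreadable from compound 1 to compound 2 cannot be sized, since the limit of > 100000 nM in this assay, at which 2 of the 3 values shown sit, holds both values. Among the compounds with values here, compound 3 `COc1ccc(N(C)c2nc(Cl)nc3c2ncn3Cc2cc(OC)cc(OC)c2)cc1` is the one compound with a number in this assay, where compound 3 gives 69000 nM. The difference between the cores of compound 1 and compound 3 is not broken down here.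

Compound 4 `COc1ccc(N(C)c2nc(Cl)nc3c2ncn3Cc2cc(OC)c(OC)c(OC)c2)cc1` has not yet been measured. It differs from compound 3 by methoxy in place of hydrogen on an aromatic carbon. This is the same kind of change as that from compound 1 to compound 2, but not the same: in the earlier pair the entering methoxy sits ortho to a methoxy group and meta to a large group, whereas in compound 4 it sits ortho to two methoxy groups and para to a large group. The earlier step gives no readable size to lean on, so the expectation for compound 4 rests on the value of compound 3, 69000 nM, with a step of about a 1.4-fold lower number from compound 3 to compound 4 (0.14 log units; within the scatter) expected. Compound 4 is estimated at 50000 nM in this assay, expected to fall between 15000 nM and 150000 nM.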

Compound 4, concentration for 50% growth inhibition: 85000 nM
Compound 4: middle estimate off by 1.7-fold (0.23 log units), on the low side, within the range that was stated.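

In this assay, methoxy in place of hydrogen on the ring of compound 3, ortho to two methoxy groups and para to a large group, gives a 1.2-fold higher number from compound 3 to compound 4 (0.09 log units; within the scatter), so on this core the two compounds cannot be told apart. The same kind of change on the core of compound 1 offers no size to compare with this one, because both values of that pair are limits and the step between them cannot be read: the limit of > 100000 nM in this assay, at which 2 of the 4 values shown sit. The new step therefore describes one position on one core; it does not show that the change carries over from one core to another, and the entering methoxy also sits at a different place in the earlier pair.

The compounds shown leave open whether a different group on this ring, such as a hydroxyl, an amine or a carboxylic acid, would give a value clearly apart from that of compound 3, 69000 nM. They also leave open what the chlorine on the core of compound 3 contributes alone, as no pair shown differs in that one place.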